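Swapping Chloro for Ethoxy on Compound 3

A few compounds are considered here, and "the series" means these few. Any claim that something is new, unique, unknown or untested is made for them only; others in the source may bear on it.

Within the data shown here, in a functional assay on Jurkat cells (Homo sapiens) for antiproliferative activity, read by MTT assay, with a stated time of 72 h (on this read-out higher numbers stand for weaker inhibition and lower numbers for stronger inhibition), compound 3, `COc1cc(C(=O)c2sc3ccccc3c2Nc2ccc(Cl)cc2)cc(OC)c1OC`, gives 1900 nM, the lowest of three numbers so far. The others are compound 1, `COc1ccc(-c2c(C(=O)c3cc(OC)c(OC)c(OC)c3)sc3ccccc23)c(OC)c1`, at 4000 nM and compound 2, `CCOc1ccc(-c2c(C(=O)c3cc(OC)c(OC)c(OC)c3)sc3ccccc23)cc1`, at 4100 nM. Compound 4, `CCOc1ccc(Nc2c(C(=O)c3cc(OC)c(OC)c(OC)c3)sc3ccccc23)cc1`, keeps the core and the amino link of compound 3 and differs in one place: ethoxy in place of chloro on an aromatic carbon. This puts ethoxy in place of chloro on an aromatic carbon, para to a large group.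

Among the measured compounds shown here, no measured step makes this exact swap, so the evidence is indirect. Two modest steps introduce the (4-chlorophenyl)amino group: a 2.1-fold lower number from compound 1 to compound 3 (0.32 log units; beyond the scatter) and a 2.2-fold lower number from compound 2 to compound 3 (0.33 log units; beyond the scatter). Another step, a 1.0-fold higher number from compound 1 to compound 2 (0.01 log units; within the scatter), stays within the scatter and involves the 4-ethoxyphenyl group. The data cannot show whether the amino link or the chloro goes with the lower number of compound 3, so compound 4 may keep that small advantage or lose it. The expected step is a 1.3-fold lower number from compound 3 to compound 4 (0.10 log units; within the scatter), which means that no change beyond the scatter is expected. For compound 4 the estimated value in this assay is 1500 nM, with an expected range from 300 nM to 5000 nM.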

Compound 4, half-maximal inhibitory concentration: 300 nM
The estimate for compound 4 lay 5.0-fold (0.70 log units) above the measured number; the range from low to high includes it.
By their numbers in this assay, from the lowest: compound 4; then compound 3; then compounds 1 and 2 (each within the scatter of the next).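

In this assay, ethoxy in place of chloro, para to a large group, gives a 6.3-fold lower number from compound 3 to compound 4 (0.80 log units; beyond the scatter) with the amino link held fixed, so the group at this position can move the number beyond the scatter on its own. Among these compounds, this also separates two things that the earlier compounds left tangled: the (4-chlorophenyl)amino group gave only a 2.2-fold lower number from compound 2 to compound 3 (0.33 log units; beyond the scatter) and the (4-ethoxyphenyl)amino group gives a 14-fold lower number from compound 2 to compound 4 (1.14 log units; beyond the scatter) against the same starting point, so the amino link and the ethoxy together go with far the lower number. Set against the 2,4-dimethoxyphenyl group, the (4-ethoxyphenyl)amino group likewise gives a 13-fold lower number from compound 1 to compound 4 (1.12 log units; beyond the scatter) and stands as the lowest number of the four compounds.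

No measurement here bears on why ethoxy goes with the lower number at this position. As far as these compounds go, with only chloro and ethoxy to compare on this ring of the amino series, it stays open whether a longer chain such as propoxy or a group such as an amine would lower the number further or raise it again.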